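Compound 3 to compound 4: hydroxy in place of amino

A few compounds are considered here, and "the series" means these few. Any claim that something is new, unique, unknown or untested is made for them only; others in the source may bear on it.

Measured in an ADME assay on the whole organism (plasma) for pharmacokinetics, with Rattus norvegicus as the target, with a stated time of 6 h, at a dose of 10 mg/kg by the oral route; on this read-out lower numbers stand for lower exposure and higher numbers for higher exposure at the dose given:
- compound 1 `O=c1c(OC2CCCC2)c(N2CCN(S(=O)(=O)Cc3ccncc3)CC2)cnn1-c1cc(F)cc(F)c1`: 20 ng.h/mL
- compound 2 `Nc1ccc(CS(=O)(=O)N2CCN(c3cnn(-c4cc(F)cc(F)c4)c(=O)c3OC3CCCC3)CC2)cc1`: 8100 ng.h/mL
- compound 3 `Nc1cccc(CS(=O)(=O)N2CCN(c3cnn(-c4cc(F)cc(F)c4)c(=O)c3OC3CCCC3)CC2)c1`: 5700 ng.h/mL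

Compound 3 belongs to the upper pair of these numbers. The gap within that pair is a 1.4-fold lower number from compound 2 to compound 3 (0.15 log units; within the scatter). Against the remaining compound, the step is a 290-fold higher number from compound 1 to compound 3 (2.45 log units; beyond the scatter).

The next structure is compound 4 `O=c1c(OC2CCCC2)c(N2CCN(S(=O)(=O)Cc3cccc(O)c3)CC2)cnn1-c1cc(F)cc(F)c1`, which carries hydroxy in place of amino on an aromatic carbon. The change is hydroxy in place of amino on an aromatic carbon, meta to a large group.

Among the compounds with values here, no measured step makes this exchange, so the evidence is indirect. The nearest steps are a 410-fold higher number from compound 1 to compound 2 (2.61 log units; beyond the scatter) and a 290-fold higher number from compound 1 to compound 3 (2.45 log units; beyond the scatter), both large, and they show that this assay can move far when the aromatic group on the chain carbon changes. Among these three compounds, the two high numbers belong to the aminophenyl compounds, and compound 4 has no amino group. A drop beyond the scatter is therefore expected, though smaller than those two large steps, and the uncertainty is wide.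

The estimated step is a 4.8-fold lower number from compound 3 to compound 4 (0.68 log units; beyond the scatter). For compound 4 the estimated value is 1200 ng.h/mL, with an expected range of 150 ng.h/mL to 5000 ng.h/mL.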

Compound 4, area under the concentration-time curve: "below limit of detection" (no number reported)
The entry for compound 4 holds no number, and the estimate cannot be compared.
By their numbers in this assay, from the lowest: compound 1; then compounds 3 and 2 (each within the scatter of the next).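

In this assay, within the data shown here, the entry for compound 4 holds no number, so no step between compound 4 and compound 1, compound 2 or compound 3 can be read. Nothing measured here bears on this result. The compounds shown leave open how far compound 4 lies from compound 3 on this read-out.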